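The compounds below may be only part of what the source reports. "The series", "measured", "known", "first", "only" and "open" are said of these compounds alone.

Compound 1 `O=C(Nc1cccc(-c2oc3cc(-c4ccc(F)cc4)ccc3c(=O)c2O)c1)c1ccc(F)cc1F` gives 10700 nM in a functional assay on HeLa cells (Homo sapiens) for antiproliferative activity, read by CCK-8 assay, with a stated time of 72 h; a lower number here means a stronger inhibitor, a higher number a weaker inhibitor. Among the three measured compounds it stands second highest: compound 2 `COc1ccccc1C(=O)Nc1cccc(-c2oc3cc(-c4ccc(F)cc4)ccc3c(=O)c2O)c1` gives 14100 nM, and compound 3 `Cc1cccc(C(=O)Nc2cccc(-c3oc4cc(-c5ccc(F)cc5)ccc4c(=O)c3O)c2)c1` gives 6650 nM. The step of a 1.3-fold higher number from compound 1 to compound 2 (0.12 log units; within the scatter) and the step of a 1.6-fold lower number from compound 1 to compound 3 (0.21 log units; within the scatter) both remain within the scatter, while the step of a 2.1-fold lower number from compound 2 to compound 3 (0.33 log units; beyond the scatter) is modest. Compound 4 `COc1cc(OC)cc(C(=O)Nc2cccc(-c3oc4cc(-c5ccc(F)cc5)ccc4c(=O)c3O)c2)c1` differs from compound 1 by 3,5-dimethoxyphenyl in place of 2,4-difluorophenyl on a carbonyl carbon. The two measured steps that exchange the group on a carbonyl carbon from compound 1, namely a 1.3-fold higher number from compound 1 to compound 2 (0.12 log units; within the scatter) and a 1.6-fold lower number from compound 1 to compound 3 (0.21 log units; within the scatter), were small, so no step beyond the scatter is expected in this assay for compound 4. Compound 4 is therefore estimated at 10000 nM, with a range of 5000 nM to 20000 nM. The implied step a 1.1-fold lower number from compound 1 to compound 4 (0.03 log units; within the scatter) is expected to stay within the scatter.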

Compound 4, half-maximal inhibitory concentration: 2700 nM
Compound 4: middle estimate off by 3.7-fold (0.57 log units), on the high side; the whole stated range lies above it.
By their numbers in this assay, from the lowest: compound 4; then compounds 3, 1 and 2 (each within the scatter of the next, the first and the last beyond it).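

In this assay, among the compounds shown here, the group on the carbonyl carbon proves able to shift the number beyond the scatter from compound 1 (a 4.0-fold lower number from compound 1 to compound 4 (0.60 log units; beyond the scatter)), a shift the earlier steps from compound 1 did not show. The 3,5-dimethoxyphenyl group also stands apart from the 3-methylphenyl group (a 2.5-fold lower number from compound 3 to compound 4 (0.39 log units; beyond the scatter)) and the 2-methoxyphenyl group (a 5.2-fold lower number from compound 2 to compound 4 (0.72 log units; beyond the scatter)), which leaves compound 4 lowest of the four. No evidence is available that accounts for this shift.

What the compounds shown leave open is whether 3-methoxyphenyl would match 3,5-dimethoxyphenyl, and how a phenyl group carrying an amine or a carboxylic acid would read here.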